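Swapping the bromophenyl arm of compound 1 for a dimethylphenyl

This account rests on a few compounds, and the source may have more. Where it says the series, first, only, none or still open, it means among the compounds named here.

Measured so far: compound 1, `Cc1ccc(S/C(=C/c2ccc(Br)cc2)C(=O)c2ccc(Cl)cc2)cc1`, gives 25000 nM; compound 2, `O=C(/C(=C\c1ccc(Br)cc1)Sc1ccc(Br)cc1)c1ccc(Cl)cc1`, gives 1000 nM.

In a functional assay on DU-145 cells (Homo sapiens) for inhibition, read by trypan blue exclusion, with a stated time of 96 h (a higher number here means a weaker inhibitor of growth, a lower number a stronger inhibitor of growth), compound 1 stands highest of the two numbers; the nearest is compound 2, reached by a 25-fold lower number from compound 1 to compound 2 (1.40 log units; beyond the scatter), which is bromo in place of methyl on an aromatic carbon. Compound 3, `Cc1ccc(S/C(=C/c2cc(C)cc(C)c2)C(=O)c2ccc(Cl)cc2)cc1`, has not been measured. It differs from compound 1 as 3,5-dimethylphenyl in place of 4-bromophenyl on a double-bonded chain carbon bound to a double-bonded chain carbon. For the measured compounds named here, the single measured step touches a different part of the shared core, so it does not bear directly on this change; it shows only that a change on one aromatic ring of compound 1 can shift the number by a large amount. Nothing measured speaks for the 3,5-dimethylphenyl group. Compound 3 is therefore expected to stay near compound 1, with wide uncertainty, an expected step of a 1.2-fold higher number from compound 1 to compound 3 (0.08 log units; within the scatter). The estimate for compound 3 is 30000 nM, within 8000 nM to 100000 nM.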

Compound 3, concentration for 50% growth inhibition: 50000 nM
Compound 3: the middle estimate sits 1.7-fold (0.22 log units) below what was measured, within the range that was stated.
By their numbers in this assay, from the lowest: compound 2; then compounds 1 and 3 (each within the scatter of the next).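

In this assay, placing 3,5-dimethylphenyl in place of 4-bromophenyl on a double-bonded chain carbon bound to a double-bonded chain carbon gives a 2.0-fold higher number from compound 1 to compound 3 (0.30 log units; within the scatter), so this arm tolerates the loss of its bromine and the arrival of two methyl groups without a change that can be told from the scatter. This contrasts with the large step on the other aromatic ring, a 25-fold lower number from compound 1 to compound 2 (1.40 log units; beyond the scatter), and shows that not every aromatic change on compound 1 moves the number that far. Nothing at hand explains why the two arms differ in this way.

As far as these compounds go, whether this position would accept an arm carrying an amine or a carboxylic acid remains open. Also open, from the compounds shown here alone, is whether bromo in place of methyl on the other ring would give a similar step when compound 3, with its 3,5-dimethylphenyl arm, is the starting point.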